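Two formyl groups in place of a methoxy on the shared core

The source may report more compounds than this note shows. Statements on the series, on what has been measured and on what is new or still open speak of the compounds shown alone.

The series is followed in a functional assay on MDA-MB-231 cells (Homo sapiens) for inhibition, read by MTT assay, with a stated time of 72 h; on this read-out lower numbers stand for stronger inhibition and higher numbers for weaker inhibition. Going by the values given here, compound 1 `COc1ccc(C=c2s/c(=C3\C(=O)Nc4cc(F)ccc43)n(CCN(C)C)c2=O)cc1` gives 2090 nM in this assay, the higher of the two numbers recorded; the only other measured member, compound 2 `CCN(CC)CCCn1c(=O)c(=Cc2ccc(F)c(F)c2)s/c1=C1\C(=O)Nc2ccc(F)cc21`, gives 1220 nM, and the two values lie within the usual scatter of one another, so no difference between them can be claimed. Among the compounds with values here, no single-change step between measured compounds is available, and compound 2 differs from compound 1 in more than one place, so nothing about the effect of any one change can be read from the measured pair.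

Compound 3 `CN(C)CCn1c(=O)c(=Cc2ccc(C=O)c(C=O)c2)s/c1=C1\C(=O)Nc2cc(F)ccc21` has not yet been measured in this assay. It differs from compound 1 in one place: 3,4-diformylphenyl in place of 4-methoxyphenyl on a double-bonded chain carbon bound to an aromatic carbon. Within the data shown here, with no measured step to draw on, the size and direction of the change in this assay are unknown; a shift not clearly beyond the scatter is expected, and the estimate therefore stays close to the number for compound 1 while allowing a broad spread. This corresponds to an expected step of a 1.4-fold higher number from compound 1 to compound 3 (0.16 log units; within the scatter). Compound 3 is thus expected to give about 3000 nM in this assay, with a likely range from 900 nM to 10000 nM.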

Compound 3, half-maximal inhibitory concentration: 2420 nM
For compound 3 the middle estimate is 1.2-fold (0.09 log units) above the measured one; low and high end bracket the measured number.
By their numbers in this assay, from the lowest: compounds 2, 1 and 3 (each within the scatter of the next).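

In this assay, putting 3,4-diformylphenyl in place of 4-methoxyphenyl on a double-bonded chain carbon bound to an aromatic carbon gives a 1.2-fold higher number from compound 1 to compound 3 (0.06 log units; within the scatter), the first single-place step available in this series. It shows that, at this position, a group of 10 heavy atoms with 2 hydrogen-bond acceptors and a group of 8 heavy atoms with 1 hydrogen-bond acceptor cannot be told apart on this read-out, so this exchange has no effect that can be claimed. No measurement at hand gives any property of the two groups that could account for this result.

This single step says nothing about whether a different replacement at the same position, such as an amine or a carboxylic acid in place of the 3,4-diformylphenyl group, would give a number beyond the scatter. As far as these compounds go, compound 2 still differs from both compound 1 and compound 3 in more than one place, so the contribution of the chain on the ring nitrogen, such as a longer chain with a different amine, remains open as well.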